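A ketone-to-amide change and its expected effect

The source may report more compounds than this note shows. Statements on the series, on what has been measured and on what is new or still open speak of the compounds shown alone.

Three compounds sharing one core have been measured in a functional assay on HeLa cells (Homo sapiens) for antiproliferative activity, read by MTT assay, with a stated time of 48 h; on this read-out higher numbers stand for weaker inhibition and lower numbers for stronger inhibition:

Compound 1, `COc1cc(-c2nnc(SCC(=O)c3ccccc3)n2N)cc(OC)c1OC`: > 100000 nM
Compound 2, `COc1cc(-c2nnc(SCC(=O)c3ccc(C)cc3)n2N)cc(OC)c1OC`: 2940 nM
Compound 3, `COc1ccc(C(=O)CSc2nnc(-c3cc(OC)c(OC)c(OC)c3)n2N)cc1`: 17400 nM

The value given for compound 1 is a limit of the assay rather than a number (the limit of > 100000 nM in this assay, at which 1 of the 3 values shown sits). Of the two numbers, compound 3 has the higher one; the difference is a 5.9-fold higher number from compound 2 to compound 3 (0.77 log units; beyond the scatter). The remaining steps are an at least 34-fold lower number from compound 1 to compound 2 (1.53 log units; beyond the scatter) and an at least 5.7-fold lower number from compound 1 to compound 3 (0.75 log units; beyond the scatter).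

Compound 4, `COc1cc(-c2nnc(SCC(=O)NCc3ccc(C)cc3)n2N)cc(OC)c1OC`, has not yet been measured in this assay. It differs from compound 3 in one place: (4-methylbenzyl)amino in place of 4-methoxyphenyl on a carbonyl carbon. Within the data shown here, none of the measured steps makes this change on its own; the nearest relative is a 5.9-fold higher number from compound 2 to compound 3 (0.77 log units; beyond the scatter), which concerns only the substituent on the aromatic ring, whereas compound 4 also alters what is attached to the carbonyl carbon. The methyl-bearing ring of compound 4 matches that of compound 2 rather than that of compound 3. On that slender basis a modest lowering is expected, a 1.9-fold lower number from compound 3 to compound 4 (0.29 log units; within the scatter), with wide uncertainty. Compound 4 is therefore estimated at 9000 nM, within 1500 nM to 60000 nM.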

Compound 4, half-maximal inhibitory concentration: > 100000 nM
Compound 4: no number, only a limit (the forecaster's own chance of this, stated with the estimate: 10%); at least 11-fold (1.04 log units) between middle value and limit.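

In this assay, among these compounds, the earlier compounds varied only the substituent on the aromatic ring, whereas this result shows that the group on the carbonyl carbon also matters: (4-methylbenzyl)amino in place of 4-methylphenyl gives an at least 34-fold higher number from compound 2 to compound 4 (1.53 log units; beyond the scatter), and in place of 4-methoxyphenyl it gives an at least 5.7-fold higher number from compound 3 to compound 4 (0.75 log units; beyond the scatter). The methyl-bearing ring that compound 4 shares with compound 2 is therefore not enough on its own to keep a measurable number in this series. Compound 4 gives only a limit of the assay, not a number, and the step from compound 1 to compound 4 cannot be read, as both stand at that limit: the limit of > 100000 nM in this assay, at which 2 of the 4 values shown sit.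

The compounds shown do not separate the effect of the amide nitrogen from that of the benzyl chain, as both enter together in compound 4. A (4-methylphenyl)amino group on the carbonyl carbon, or a 4-methylbenzyl group on a ketone carbonyl, would each change only one of these features, and an N-methyl amide would test the role of the amide hydrogen.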